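This account rests on a few compounds, and the source may have more. Where it says the series, first, only, none or still open, it means among the compounds named here.

Three compounds of this series share one core and differ only in the aryl group attached to the carbonyl carbon. In a functional assay on PC-3 cells (Homo sapiens) for antiproliferative activity, read by MTT assay, with a stated time of 48 h (on this read-out lower numbers stand for stronger inhibition and higher numbers for weaker inhibition), compound 1 `COc1cc(-c2nnc(SCC(=O)c3ccc(Cl)cc3)n2N)cc(OC)c1OC` gives > 100000 nM, which is a limit of the assay and not a number. Compound 2 `COc1cc(-c2nnc(SCC(=O)c3ccc(C(F)(F)F)cc3)n2N)cc(OC)c1OC` likewise returns only a limit, > 100000 nM. Compound 3 `COc1cc(-c2nnc(SCC(=O)c3ccc(F)c(F)c3)n2N)cc(OC)c1OC` also returns a limit, > 100000 nM. All three values sit at the limit of > 100000 nM in this assay, at which 3 of the 3 values shown sit, so the steps a step that the two limits leave unreadable from compound 1 to compound 2, a step that the two limits leave unreadable from compound 1 to compound 3 and a step that the two limits leave unreadable from compound 2 to compound 3 give neither a size nor a direction. Compound 3 therefore stands at the limit, indistinguishable from the other two on the numbers shown. Compound 4 `COc1ccc(C(=O)CSc2nnc(-c3cc(OC)c(OC)c(OC)c3)n2N)cc1` differs from compound 3 by 4-methoxyphenyl in place of 3,4-difluorophenyl on a carbonyl carbon. Among the compounds with values here, none of the measured steps bears readably on this change, as each one runs between two limits. The step is expected to be a step that the limit leaves unreadable from compound 3 to compound 4, with a limit again the likeliest outcome. The estimate for compound 4 in this assay is 150000 nM, expected to fall between 30000 nM and 600000 nM.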

Compound 4, half-maximal inhibitory concentration: 97900 nM
For compound 4 the middle estimate is 1.5-fold (0.19 log units) above the measured one, and the stated range covers the measured number.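

In this assay compound 4, with 4-methoxyphenyl on the carbonyl carbon, is the only one of the four compounds shown to give a number, 97900 nM, rather than a limit. This position can therefore yield a readable value, yet the steps are only floors: an at least 1.0-fold lower number from compound 3 to compound 4 (0.00 log units; that floor lies within the scatter), an at least 1.0-fold lower number from compound 2 to compound 4 (0.00 log units; that floor lies within the scatter) and an at least 1.0-fold lower number from compound 1 to compound 4 (0.00 log units; that floor lies within the scatter), and none of them is shown to lie beyond the scatter. The true size of these steps stays unknown because the other three compounds rest on a limit: the limit of > 100000 nM in this assay, at which 3 of the 4 values shown sit.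

As far as these compounds go, whether a dimethylamino group or a carboxylic acid on this aromatic ring, or a longer alkoxy chain in place of the methoxy, would give a value clearly lower than that of compound 4 stays open. The shown compounds also leave open how the series responds to any change outside this aryl group.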